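Benzyloxy in place of nitro: notes on compound 3

The compounds below may be only part of what the source reports. "The series", "measured", "known", "first", "only" and "open" are said of these compounds alone.

In a functional assay on SGC-7901 cells (Homo sapiens) for antiproliferative activity, read by MTT assay, with a stated time of 72 h (on this read-out higher numbers stand for weaker inhibition and lower numbers for stronger inhibition), compound 1 `CCOC(=O)c1cc(-c2cc(OC)c(OC)c(OC)c2)c(-c2ccc(OC)cc2)s1` gives 9760 nM. Compound 2 `CCOC(=O)c1cc(-c2cc(OC)c(OC)c(OC)c2)c(-c2ccc(OC)c([N+](=O)[O-])c2)s1` gives 18100 nM, within the scatter of compound 1. Compound 3 `CCOC(=O)c1cc(-c2cc(OC)c(OC)c(OC)c2)c(-c2ccc(OC)c(OCc3ccccc3)c2)s1` carries benzyloxy in place of nitro on an aromatic carbon, ortho to a methoxy group: benzyloxy in place of nitro on an aromatic carbon. Among the compounds with values here, the only measured step at this place is a 1.9-fold higher number from compound 1 to compound 2 (0.27 log units; within the scatter), and it lies within the scatter. Within the data shown here, no benzyloxy compound has been measured, so no step beyond the scatter is expected in this assay. The expected size is a 1.3-fold lower number from compound 2 to compound 3 (0.11 log units; within the scatter). For compound 3 the estimate is 14000 nM, with an expected range of 5000 nM to 40000 nM.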

Compound 3, half-maximal inhibitory concentration: > 100000 nM
Compound 3: only a limit was reported; the forecaster's own chance of this, stated with the estimate: 10%; middle value at least 7.1-fold (0.85 log units) away from the limit.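

The place ortho to a methoxy group is not indifferent to substitution in this series. Nitro stayed within the scatter of hydrogen, but benzyloxy gives an at least 10-fold higher number from compound 1 to compound 3 (1.01 log units; beyond the scatter) and also an at least 5.5-fold higher number from compound 2 to compound 3 (0.74 log units; beyond the scatter), so this change is the first beyond the scatter here. Compound 3 is reported only as a limit in this assay: the limit of > 100000 nM in this assay, at which 1 of the 3 values shown sits.

How far compound 3 lies past that limit cannot be read. The compounds shown leave open whether a hydroxy group, an amine or a short ether such as ethoxy at this place reads like hydrogen and nitro or like benzyloxy.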